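Swapping the aryl group on the piperazine of an aminothiophene ketone

The compounds below may be only part of what the source reports. "The series", "measured", "known", "first", "only" and "open" are said of these compounds alone.

Measured so far:
compound 1 `Nc1scc(CN2CCN(c3ccc(Cl)cc3Cl)CC2)c1C(=O)c1ccc(Cl)cc1`: -54%
compound 2 `Nc1scc(CN2CCN(c3ccc(Cl)c(C(F)(F)F)c3)CC2)c1C(=O)c1ccc(Cl)cc1`: -47%

Both compounds were tested in a functional assay on CHO cells with adenosine receptor A1 (Homo sapiens) as the target, read by cAMP accumulation and immunoassay, with a stated time of 6 min, tested at 1 uM; a higher number here means a weaker effect of the compound at the concentration tested, a lower number a stronger effect. Compound 1 gives -54% and compound 2 gives -47%. Of these two numbers, that of compound 2 is the one at the upper end, with compound 1 at the other end; the step of a number 7 percentage points higher from compound 1 to compound 2 (within the scatter) lies within the scatter, so the two compounds cannot be told apart on these numbers.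

Compound 3 `Nc1scc(CN2CCN(c3ccc(OC(F)(F)F)cc3)CC2)c1C(=O)c1ccc(Cl)cc1` has not yet been measured. It differs from compound 2 in one place: 4-(trifluoromethoxy)phenyl in place of 4-chloro-3-(trifluoromethyl)phenyl on an amine nitrogen in a ring. For the measured compounds named here, the only measured step that bears on this change is the one from compound 1 to compound 2, which also swapped the aryl group on the ring nitrogen, and it was a number 7 percentage points higher from compound 1 to compound 2 (within the scatter), within the scatter. Going by the values given here, no measured step covers a trifluoromethoxy group itself, so the expectation rests on that single comparison alone.

Compound 3 is therefore expected to give -45%, with a range from -65% to -25%. The step of a number 2 percentage points higher from compound 2 to compound 3 (within the scatter) is expected to be none beyond the scatter.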

Compound 3, a percentage reported as activity, at one concentration (the size of the read-out at that concentration, not a potency): -51%
Compound 3: middle estimate off by 6 percentage points, on the high side; the range from low to high includes it.
By their numbers in this assay, from the lowest: compounds 1, 3 and 2 (each within the scatter of the next).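

In this assay the move to 4-(trifluoromethoxy)phenyl gives a number 4 percentage points lower from compound 2 to compound 3 (within the scatter), and the same group measured against 2,4-dichlorophenyl gives a number 3 percentage points higher from compound 1 to compound 3 (within the scatter), so all three aryl groups on the ring nitrogen cannot be told apart on these numbers. Compared with the earlier pair, this result widens the kind of group tested at this place: 4-(trifluoromethoxy)phenyl carries oxygen and no chlorine, and it counts one hydrogen-bond acceptor where 4-chloro-3-(trifluoromethyl)phenyl counts none, yet neither difference comes with a step beyond the scatter. Nothing available here accounts for why these three aryl groups read alike.

The compounds shown leave open whether any group at this place would separate from the others, since all three are phenyl rings bearing chlorine or fluorine-containing groups, and a plain phenyl, a pyridine ring or a phenyl carrying an amine or a carboxylic acid could test that. Each value also comes from a single concentration, so it shows only the size of the effect at that concentration, and whether any of these compounds has a stronger or weaker effect at other concentrations remains open.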